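Trifluoromethylphenyl position in a terpyridine-type series

The source may hold more compounds than are shown below. What is called first, only, known or untested is meant among the compounds shown, and "the series" means these compounds.

Measured compounds in a functional assay on DU-145 cells (Homo sapiens) for inhibition; on this read-out lower numbers stand for stronger inhibition and higher numbers for weaker inhibition:
compound 1 `Oc1ccc(-c2cc(-c3ccccc3C(F)(F)F)cc(-c3ccccc3O)n2)cc1` gives 6690 nM.
compound 2 `Oc1ccc(-c2cc(-c3cccc(C(F)(F)F)c3)cc(-c3ccccc3O)n2)cc1` reaches only a limit, > 50000 nM.
compound 3 `Oc1cccc(-c2cc(-c3ccccc3C(F)(F)F)cc(-c3cccc(O)c3)n2)c1` gives 2870 nM.

Compound 3 holds the lowest of the two numbers, with compound 1 nearer by a step beyond the scatter. The difference between the core of compound 1 and the core of compound 3 is not broken down here. Within the first pair, the change 3-(trifluoromethyl)phenyl in place of 2-(trifluoromethyl)phenyl on an aromatic carbon produces an at least 7.4-fold higher number from compound 1 to compound 2 (0.87 log units; beyond the scatter), the size of which is only a floor because of the limit of > 50000 nM in this assay, at which 1 of the 3 values shown sits.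

Compound 4 `Oc1cccc(-c2cc(-c3cccc(C(F)(F)F)c3)cc(-c3cccc(O)c3)n2)c1` differs from compound 3 by 3-(trifluoromethyl)phenyl in place of 2-(trifluoromethyl)phenyl on an aromatic carbon. This is the same kind of change as that from compound 1 to compound 2, but not the same: in compound 1 the place is meta to a 2-hydroxyphenyl group and meta to a 4-hydroxyphenyl group, whereas in compound 3 it is meta to two 3-hydroxyphenyl groups. Among the measured compounds shown here, on the single precedent, compound 4 is expected to show a 10-fold higher number from compound 3 to compound 4 (1.02 log units; beyond the scatter) in this assay, resting on compound 1 and the step of an at least 7.4-fold higher number from compound 1 to compound 2 (0.87 log units; beyond the scatter). Compound 4 is estimated at 30000 nM, between 8000 nM and 100000 nM, with a real chance that only a limit is reported.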

Compound 4, half-maximal inhibitory concentration: > 50000 nM
Compound 4: only a limit was reported (the forecaster's own chance of this, stated with the estimate: 45%); middle value at least 1.6-fold (0.22 log units) away from the limit.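

On the core of compound 3, 3-(trifluoromethyl)phenyl in place of 2-(trifluoromethyl)phenyl on an aromatic carbon gives in this assay an at least 17-fold higher number from compound 3 to compound 4 (1.24 log units; beyond the scatter), the same direction as on the core of compound 1. For compound 4 the reading of > 50000 nM is a limit and not a number. The direction of the change therefore carries across the two cores shown, but its size on either core stays unknown, and two cores do not establish a rule for the series: the same change on two cores in this assay, an at least 7.4-fold higher number (0.87 log units; beyond the scatter) from compound 1 to compound 2 and an at least 17-fold higher number (1.24 log units; beyond the scatter) from compound 3 to compound 4; the limit leaves it open whether they differ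

Within the compounds shown, only the 2-(trifluoromethyl)phenyl compounds give numbers that are not limits, so nothing shows how far the number moves among the 3-(trifluoromethyl)phenyl compounds when the hydroxyphenyl groups change. Also open, as far as these compounds go, is how the read-out responds when the trifluoromethyl group on the phenyl ring gives way to a nitrile, an amine or a carboxylic acid, on either core.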